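A few compounds are considered here, and "the series" means these few. Any claim that something is new, unique, unknown or untested is made for them only; others in the source may bear on it.

Compound 1, `CN1C[C@H]2C=C(c3cccnc3)C[C@H](C2)C1`: > 10000 nM
Compound 2, `Fc1ccc(C2=CC3CNCC(C2)C3)cn1`: 85 nM

For the measured compounds named here, in an in vitro functional assay on SH-EP1 cells for agonist activity at Neuronal acetylcholine receptor; alpha4/beta2 (Homo sapiens), read by FLIPR and calcium flux (on this read-out lower numbers stand for an effect already at smaller amounts and higher numbers for an effect only at larger amounts of compound), compound 2 gives 85 nM, the only value here that is a number. For compound 1 the assay reports only a limit, > 10000 nM. Compound 3, `CN1CC2C=C(c3ccc(F)nc3)CC(C2)C1`, differs from compound 2 by methyl in place of hydrogen on an amine nitrogen in a ring. Going by the values given here, no measured pair differs in just this way, so the size of the step is open. A loss of potency is expected, because compound 1, which also carries a methyl on that ring nitrogen, sits at the limit of > 10000 nM in this assay, at which 1 of the 2 values shown sits. Compound 3 is therefore expected near 2000 nM, within 300 nM to 10000 nM, a step of a 24-fold higher number from compound 2 to compound 3 (1.37 log units; beyond the scatter).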

Compound 3, half-maximal effective concentration: > 10000 nM
Compound 3: a limit, no number; the forecaster's own chance of this, stated with the estimate: 30%; at least 5.0-fold (0.69 log units) between middle value and limit.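

For the compounds shown here, for the first time, a single pair isolates this change: with methyl in place of hydrogen on the amine nitrogen in the ring, this assay shows an at least 110-fold higher number from compound 2 to compound 3 (2.07 log units; beyond the scatter). This step is a bound and not an exact size, since compound 3 gives only a limit. Both compounds shown with this methyl now stand at that limit: the limit of > 10000 nM in this assay, at which 2 of the 3 values shown sit.

On these data alone, the true size of the step stays open. So does whether an ethyl group or a longer chain on this nitrogen would give a measurable number.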